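The compounds below may be only part of what the source reports. "The series", "measured", "known", "first", "only" and "open" are said of these compounds alone.

Three compounds have been measured in a functional assay on HCT-116 cells (Homo sapiens) for cytotoxicity, read by sulforhodamine B assay, with a stated time of 24 h; a higher number here means a weaker inhibitor, a lower number a stronger inhibitor:

Compound 1 `N#CCC(=O)N/N=C1\C(=O)Nc2ccc(S(=O)(=O)N3CCOCC3)cc21` gives 10300 nM.
Compound 2 `O=C1Nc2ccc(S(=O)(=O)N3CCOCC3)cc2/C1=N/c1ccc(Br)cc1` gives 15300 nM.
Compound 3 `Cc1ccc(S(=O)(=O)N/N=C2\C(=O)Nc3ccc(S(=O)(=O)N4CCOCC4)cc32)cc1` gives 23400 nM.

Compound 1 has the lowest of the three numbers. Its nearest neighbour is compound 2, reached by a 1.5-fold higher number from compound 1 to compound 2 (0.17 log units; within the scatter), a gap that stays within the scatter, so the two cannot be ranked against each other. Compound 3 stands furthest off, by a 2.3-fold higher number from compound 1 to compound 3 (0.36 log units; beyond the scatter), a modest step beyond the scatter.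

Compound 4 `O=C1Nc2ccc(S(=O)(=O)N3CCOCC3)cc2/C1=N/NC(=O)c1ccccc1` is not yet measured in this assay. Its difference from compound 1 is phenyl in place of cyanomethyl on a carbonyl carbon. Both measured steps touch the same end of the shared core: in compound 2 a 4-bromophenyl replaces the whole ((cyanomethyl)carbonyl)amino group on the double-bonded nitrogen, and in compound 3 a (4-methylphenyl)sulfonyl replaces the (cyanomethyl)carbonyl. Each time an aromatic ring entered at this position the number moved higher, once within the scatter and once modestly beyond it. A benzoyl in place of the (cyanomethyl)carbonyl is a change of the same kind, so a small shift toward a higher number, at most about the size seen for compound 3, is the expectation. Compound 4 is therefore estimated at 15000 nM, most likely between 6000 nM and 40000 nM, which corresponds to an expected step of a 1.5-fold higher number from compound 1 to compound 4 (0.16 log units; within the scatter).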

Compound 4, half-maximal inhibitory concentration: 28900 nM
Beside the measured number, compound 4's estimate is 1.9-fold (0.28 log units) below it; the range from low to high includes it.
By their numbers in this assay, from the lowest: compounds 1, 2, 3 and 4 (each within the scatter of the next, the first and the last beyond it).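

In this assay, keeping the carbonyl and the amide-type nitrogen and exchanging only cyanomethyl for phenyl still produces a modest step beyond the scatter (a 2.8-fold higher number from compound 1 to compound 4 (0.45 log units; beyond the scatter)), so this change alone is enough; the earlier step to compound 3 had also replaced the carbonyl, and the step to compound 2 had removed the whole ((cyanomethyl)carbonyl)amino group. The groups bearing an aromatic ring are not told apart here: benzoyl in place of (4-methylphenyl)sulfonyl gives a 1.2-fold higher number from compound 3 to compound 4 (0.09 log units; within the scatter), and benzamido in place of 4-bromophenyl gives a 1.9-fold higher number from compound 2 to compound 4 (0.28 log units; within the scatter). Compound 1 therefore stands apart from compound 3 and compound 4, while compound 2 goes against a clean split, lying within the scatter of compound 1 as well as of compound 4. Nothing shown accounts for these steps.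

Going by these compounds, whether a methyl or a longer alkyl chain on the carbonyl carbon would read like compound 1 or like compound 4 remains open, so loss of the nitrile and entry of the ring stay unseparated. On these data alone, how a methoxy or a carboxylic acid on the phenyl of compound 4 would read is also open.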